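The source may report more compounds than this note shows. Statements on the series, on what has been measured and on what is new or still open speak of the compounds shown alone.

Compound 2, `COc1ccc2c(=O)c(/C=C/C(=O)NCc3ccc(C)cc3)coc2c1`, carries a methoxy group on its core and a 4-methylbenzyl group on the amide-type nitrogen. In a functional assay on Huh-7 cells (Homo sapiens) for inhibition, read by MTT assay, with a stated time of 48 h (on this read-out higher numbers stand for weaker inhibition and lower numbers for stronger inhibition), compound 2 gives 14300 nM. Compound 1, `COc1ccc2c(=O)c(/C=C/C(=O)Nc3ccccc3)coc2c1`, differs from compound 2 by phenyl in place of 4-methylbenzyl on an amide-type nitrogen, and in this assay compound 1 gives 9050 nM. That change made a 1.6-fold lower number from compound 2 to compound 1 (0.20 log units; within the scatter), so the two values are treated here as alike.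

Compound 3, `Cc1ccc(CNC(=O)/C=C/c2coc3cc(O)ccc3c2=O)cc1`, differs from compound 2 by hydrogen in place of methyl on an oxygen on an aromatic ring. In this assay the reading for compound 3 is a limit, > 100000 nM, and no number stands behind it. The step is therefore only bounded, an at least 6.9-fold higher number from compound 2 to compound 3 (0.84 log units; beyond the scatter), and the bound comes from the limit of > 100000 nM in this assay, at which 1 of the 3 values shown sits.

Compound 4, `O=C(/C=C/c1coc2cc(O)ccc2c1=O)Nc1ccccc1`, has not been measured in this assay. It differs from compound 3 by phenyl in place of 4-methylbenzyl on an amide-type nitrogen, the same change that separates compound 2 from compound 1, made on the same kind of nitrogen with the same carbonyl carbon as its other neighbour. On that pair the change stayed within the scatter, and since compound 3 itself sits at a limit, compound 4 is expected to sit near that limit as well. The step from compound 3 to compound 4 is estimated as a number no higher from compound 3 to compound 4 (the limit leaves the size open), resting on compound 1 and compound 2 and their step of a 1.6-fold lower number from compound 2 to compound 1 (0.20 log units; within the scatter). In this assay compound 4 is therefore estimated at 100000 nM, with a range from 40000 nM to 300000 nM, and a real chance that only a limit is reported.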

Compound 4, half-maximal inhibitory concentration: 3880 nM
The estimate for compound 4 lay 26-fold (1.41 log units) above the measured number, outside the stated range (below it).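

Replacing 4-methylbenzyl with phenyl on the amide-type nitrogen did not carry over from one core to the other in this assay. It gave an at least 25-fold lower number from compound 3 to compound 4 (1.41 log units; beyond the scatter) on the core with hydrogen on the oxygen, whereas on the core with methyl on the oxygen the two values remained alike, so the outcome of this change depended on the core: the same change on two cores in this assay, a 1.6-fold lower number (0.20 log units; within the scatter) from compound 2 to compound 1 and an at least 25-fold lower number (1.41 log units; beyond the scatter) from compound 3 to compound 4, at least 16-fold (1.21 log units) apart, beyond the scatter of two such steps

Read the other way, replacing methyl with hydrogen on the oxygen gave a 2.3-fold lower number from compound 1 to compound 4 (0.37 log units; beyond the scatter) with phenyl on the nitrogen, which runs opposite to the bounded step seen with 4-methylbenzyl, so neither change can be transferred as a fixed increment within these four compounds: the same change on two cores in this assay, an at least 6.9-fold higher number (0.84 log units; beyond the scatter) from compound 2 to compound 3 and a 2.3-fold lower number (0.37 log units; beyond the scatter) from compound 1 to compound 4, at least 16-fold (1.21 log units) apart, beyond the scatter of two such steps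

The reading for compound 3 is a limit, so the true size of the gaps stays open, and this single square of compounds shows that the two changes are coupled without showing why: the limit of > 100000 nM in this assay, at which 1 of the 4 values shown sits.

The compounds shown leave open whether the coupling follows from the methyl group or from the extra carbon linking the ring to the nitrogen, which an unsubstituted benzyl group or a 4-methylphenyl group could separate. They also leave open how a longer chain such as phenethyl on that nitrogen, or an ethoxy group in place of the methoxy group, would behave on either core.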